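This account rests on a few compounds, and the source may have more. Where it says the series, first, only, none or still open, it means among the compounds named here.

Working notes on the series. The three measured compounds share one core; compound 1 `COc1ccc(S(=O)(=O)N2CCc3cccc(-c4ccc(N)cc4)c32)cc1` carries a 4-aminophenyl, compound 2 `COc1ccc(-c2cccc3c2N(S(=O)(=O)c2ccc(OC)cc2)CC3)cc1` a 4-methoxyphenyl and compound 3 `COc1ccc(S(=O)(=O)N2CCc3cccc(-c4cccnc4)c32)cc1` a pyridin-3-yl on that core. In a functional assay on NCI-H460 cells (Homo sapiens) for inhibition, with a stated time of 72 h (a lower number here means a stronger inhibitor, a higher number a weaker inhibitor), compound 1 gives 288 nM, compound 2 gives 302 nM and compound 3 gives 89.6 nM. Among these three numbers compound 1 holds the second highest; the step of a 1.0-fold higher number from compound 1 to compound 2 (0.02 log units; within the scatter) is within the scatter, whereas a 3.2-fold lower number from compound 1 to compound 3 (0.51 log units; beyond the scatter) and a 3.4-fold lower number from compound 2 to compound 3 (0.53 log units; beyond the scatter) are modest steps beyond it.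

Compound 4 `COc1ccc(S(=O)(=O)N2CCc3cccc(-c4ccc(O)cc4)c32)cc1` is the next analogue and differs from compound 1 only by hydroxy in place of amino on an aromatic carbon. Among the measured compounds shown here, the step that bears on this change is the one from compound 1 to compound 2, an exchange of the same group on the same ring, which gave a 1.0-fold higher number from compound 1 to compound 2 (0.02 log units; within the scatter). Since that exchange left the number unchanged within the scatter, the change to compound 4 is expected to give no step beyond the scatter in this assay, that is a 1.0-fold lower number from compound 1 to compound 4 (0.01 log units; within the scatter). For compound 4 the expected value is therefore 280 nM, with a range of 140 nM to 560 nM.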

Compound 4, half-maximal inhibitory concentration: 114 nM
Estimate against measurement, compound 4: 2.5-fold (0.39 log units) above; measured number below the stated range.
By their numbers in this assay, from the lowest: compounds 3 and 4 (each within the scatter of the next); then compounds 1 and 2 (each within the scatter of the next).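

The hydroxy group does not behave like the amino and methoxy groups at this position, although those two could not be told apart: the series shows a 2.5-fold lower number from compound 1 to compound 4 (0.40 log units; beyond the scatter) and also a 2.6-fold lower number from compound 2 to compound 4 (0.42 log units; beyond the scatter) on the same ring. Among the compounds shown here, removing the methyl from the oxygen therefore matters here, and the single amino-to-methoxy exchange gave no general reading of this position. With a 1.3-fold higher number from compound 3 to compound 4 (0.10 log units; within the scatter) as well, a phenyl ring at this place can sit level with pyridin-3-yl, so the earlier gap does not separate the two ring types as such. Nothing available accounts for the difference between hydroxy and the other two groups.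

On these data alone, it remains open whether a phenyl ring without a substituent, or one bearing a carboxylic acid or a fluorine, would sit with compound 3 and compound 4 or with compound 1 and compound 2. As far as these compounds go, whether the hydroxy step carries over to another core also stays open.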